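Compound 4: 1H-pyrazol-1-yl in place of methylsulfanyl

A few compounds are considered here, and "the series" means these few. Any claim that something is new, unique, unknown or untested is made for them only; others in the source may bear on it.

In an ADME assay on microsomes from liver (Mus musculus, strain CD1) for metabolic stability, read by HPLC, using NADPH, with a stated time of 30 min (a higher number here means faster removal of the compound, a lower number slower removal), compound 1 `COc1cccc(NC(=O)c2nnn(Cc3ccc(C#N)cc3)c2N)c1` gives 2.5 mL.min-1.g-1, compound 2 `COc1cccc(NC(=O)c2nnn(Cc3ccc(C(C)C)cc3)c2N)c1` gives 3.2 mL.min-1.g-1 and compound 3 `COc1cccc(NC(=O)c2nnn(Cc3ccc(SC)cc3)c2N)c1` gives 6.4 mL.min-1.g-1. Compound 3 stands clear of compound 1 only. The widest step at this place, a 2.6-fold higher number from compound 1 to compound 3 (0.41 log units; beyond the scatter), is modest, and the others, a 2.0-fold higher number from compound 2 to compound 3 (0.30 log units; within the scatter) and a 1.3-fold higher number from compound 1 to compound 2 (0.11 log units; within the scatter), stay within the scatter. Compound 4 `COc1cccc(NC(=O)c2nnn(Cc3ccc(-n4cccn4)cc3)c2N)c1` carries 1H-pyrazol-1-yl in place of methylsulfanyl on an aromatic carbon. For the measured compounds named here, no measured compound has a ring at this place, so the expectation rests on these steps alone: a small downward move, not beyond the scatter. The expected step is a 1.6-fold lower number from compound 3 to compound 4 (0.20 log units; within the scatter). The estimate for compound 4 is 4 mL.min-1.g-1, with an expected range of 1.8 mL.min-1.g-1 to 9 mL.min-1.g-1.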

Compound 4, intrinsic clearance in microsomes: 2.3 mL.min-1.g-1
The estimate for compound 4 lay 1.7-fold (0.24 log units) above the measured number; the measured number falls inside the stated range.
By their numbers in this assay, from the lowest: compounds 4, 1, 2 and 3 (each within the scatter of the next, the first and the last beyond it).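

In this assay the step of a 2.8-fold lower number from compound 3 to compound 4 (0.44 log units; beyond the scatter) separates the first ring at this place from methylsulfanyl, while a 1.4-fold lower number from compound 2 to compound 4 (0.14 log units; within the scatter) and a 1.1-fold lower number from compound 1 to compound 4 (0.04 log units; within the scatter) leave it level with isopropyl and cyano. A five-membered aromatic ring with 2 hetero atoms thus stays within the scatter of compound 1 and compound 2, and only compound 3 lies clear of compound 4. No measurement offered here explains these steps. From the compounds shown here alone, whether a phenyl ring, a pyridine ring, an amine or a carboxylic acid at this place would stay this low remains open.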